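Adding a methoxy group to compound 2

This account rests on a few compounds, and the source may have more. Where it says the series, first, only, none or still open, it means among the compounds named here.

compound 1 (`COc1cccc(/C=C/C(=O)Nc2cc(OC)c(OC)c(OC)c2)c1`) gives 11300 nM
compound 2 (`COc1cc(NC(=O)/C=C/c2ccccc2)cc(OC)c1OC`) gives > 50000 nM as a limit of the assay, not a number

Both results come from a functional assay on HeLa cells (Homo sapiens) for cytotoxicity, read by sulforhodamine B assay, with a stated time of 72 h (on this read-out higher numbers stand for weaker inhibition and lower numbers for stronger inhibition), and compound 2 stands at the limit of > 50000 nM in this assay, at which 1 of the 2 values shown sits, with no exact number. The change from compound 2 to compound 3 (`COc1ccccc1/C=C/C(=O)Nc1cc(OC)c(OC)c(OC)c1`) is methoxy in place of hydrogen on an aromatic carbon, ortho to a large group (methoxy in place of hydrogen on an aromatic carbon). Among the measured compounds shown here, the one measured step that bears on this is the loss of a methoxy placed differently from that of compound 3, which gave an at least 4.4-fold higher number from compound 1 to compound 2 (0.64 log units; beyond the scatter) and lies beyond the scatter. Read in reverse, with compound 1 at 11300 nM as the nearest measured value, that step points to a lower number, though the different placement leaves its size uncertain. The expected step is an at least 3.3-fold lower number from compound 2 to compound 3 (0.52 log units; beyond the scatter) in the direction of stronger inhibition, of similar size to the measured one. Compound 3 is estimated at 15000 nM (expected range 4000 nM to 50000 nM).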

Compound 3, half-maximal inhibitory concentration: 6100 nM
Estimate against measurement, compound 3: 2.5-fold (0.39 log units) above; the range from low to high includes it.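

In this assay, methoxy in place of hydrogen on an aromatic carbon, ortho to a large group, gives an at least 8.1-fold lower number from compound 2 to compound 3 (0.91 log units; beyond the scatter), so the gain from a methoxy on this ring is not confined to the placement in compound 1. With 2-methoxyphenyl in place of 3-methoxyphenyl, the result is a 1.9-fold lower number from compound 1 to compound 3 (0.27 log units; within the scatter), which leaves the two placements indistinguishable in this assay. Compound 2 carries a limit, not a number, so the full size of the step from it stays unknown: the limit of > 50000 nM in this assay, at which 1 of the 3 values shown sits.

From the compounds shown here alone, whether this position needs a methoxy in particular remains open, since a hydroxyl, a fluorine or an amine in the same place could give a different result. Also open, going by these compounds, is whether a second methoxy on this ring would add to the effect of the first.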